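A few compounds are considered here, and "the series" means these few. Any claim that something is new, unique, unknown or untested is made for them only; others in the source may bear on it.

Working notes on the series. Within the data shown here, the three compounds measured so far share one core and differ only in the group carried on the aromatic ring attached to it. Compound 1 `Cc1cc2nn(-c3ccccc3)c(C)c2c(=O)o1` carries hydrogen there; in a functional assay on the whole organism for inhibition, with Rattus norvegicus as the target, read by paw edema, with a stated time of 3 h, at a dose of 50 mg/kg (on this read-out lower numbers stand for less inhibition and higher numbers for more inhibition at the one dose given (going by the name of the read-out)), compound 1 gives 52.5%. Compound 2 `Cc1cc2nn(-c3ccc(Cl)cc3)c(C)c2c(=O)o1` carries chloro, and in this assay compound 2 gives 56.6%. Compound 3 `Cc1cc2nn(-c3ccc(Br)cc3)c(C)c2c(=O)o1` carries bromo, and in this assay compound 3 gives 49.5%. Compound 3 has the lowest of the three numbers, but its nearest neighbour on the scale is compound 1, and the step of a number 3 percentage points lower from compound 1 to compound 3 (within the scatter) lies within the scatter, as does the step of a number 7.1 percentage points lower from compound 2 to compound 3 (within the scatter). Across the three, nothing beyond the scatter separates hydrogen, chloro and bromo at this position.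

The next compound, compound 4 `COc1ccc(-n2nc3cc(C)oc(=O)c3c2C)cc1`, differs from compound 3 in one place: methoxy in place of bromo on an aromatic carbon. Among the measured compounds shown here, no measured step involves methoxy, so the only steps that bear on the change are the two around compound 3, a number 3 percentage points lower from compound 1 to compound 3 (within the scatter) and a number 7.1 percentage points lower from compound 2 to compound 3 (within the scatter), both within the scatter. On that basis no step beyond the scatter is expected in this assay in either direction, and the expected step is a number 2.5 percentage points higher from compound 3 to compound 4 (within the scatter). Compound 4 is estimated at 52%, with a range from 40% to 64%.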

Compound 4, a percentage reported as inhibition, in the whole organism at one dose (the size of the read-out at that dose, not a potency): 57.6%
For compound 4 the middle estimate is 5.6 percentage points below the measured one; low and high end bracket the measured number.
By their numbers in this assay, from the lowest: compounds 3, 1, 2 and 4 (each within the scatter of the next).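

In this assay, among these compounds, methoxy is the first group at this position with more than one heavy atom and with a hydrogen-bond acceptor, and it still stays within the scatter of all three earlier groups: the steps are a number 8.1 percentage points higher from compound 3 to compound 4 (within the scatter) and a number 1 percentage points higher from compound 2 to compound 4 (within the scatter) and a number 5.1 percentage points higher from compound 1 to compound 4 (within the scatter) and none of them exceeds the usual spread of repeated measurements. The earlier compounds shown here compared only hydrogen and two halogens, so the flat reading at this aromatic carbon, para to a large group, now also covers a group that brings in oxygen and has no counterpart among those three. No measurement at hand offers a reason for this flat reading.

The four compounds leave open whether a group of another kind at this position, such as an amine, a carboxylic acid or a chain longer than methoxy, would give a step beyond the scatter. They also leave open whether hydrogen, chloro, bromo and methoxy would still be indistinguishable at another dose or time, since the read-out here gives one dose and one time only.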